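This account rests on a few compounds, and the source may have more. Where it says the series, first, only, none or still open, it means among the compounds named here.

Two close relatives share one core, a dichloroacetamide joined to an aromatic ring: compound 1 `O=C(Nc1ccc(F)cc1)C(Cl)Cl` carries a fluoro group on that ring and compound 2 `O=C(Nc1ccc(Cl)cc1)C(Cl)Cl` a chloro group. For compound 1 no result was obtained in a functional assay on KB cells (Homo sapiens) for antiproliferative activity, read by MTT assay, with a stated time of 72 h (a higher number here means a weaker inhibitor, a lower number a stronger inhibitor), the entry for compound 1 reading "not determined" (no result reported). In this assay compound 2 gives 60800 nM, the only figure available, so it stands alone and counts as a weak inhibitor. Compound 3 `O=C(Nc1ccc(SC(F)(F)F)cc1)C(Cl)Cl` differs from compound 2 in one place: (trifluoromethyl)sulfanyl in place of chloro on an aromatic carbon. Among the compounds with values here, no measured pair differing in a single change exists here, so the size of this step cannot be read from the data. A modest gain in potency is expected, though one that may not exceed the usual scatter. Compound 3 is therefore estimated at 30000 nM, within 8000 nM to 120000 nM. The expected step from compound 2 to compound 3 is a 2.0-fold lower number from compound 2 to compound 3 (0.31 log units; beyond the scatter).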

Compound 3, half-maximal inhibitory concentration: 2080 nM
Compound 3: the middle estimate sits 14-fold (1.16 log units) above what was measured; the whole stated range lies above it.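

Replacing chloro with (trifluoromethyl)sulfanyl on this aromatic carbon gives a 29-fold lower number from compound 2 to compound 3 (1.47 log units; beyond the scatter) in this assay and so shows that activity depends strongly on the group at this place, which the lone figure for compound 2 could not reveal. The larger group, with 5 heavy atoms in place of 1, brings no loss of activity here but a clear gain. Nothing in the available data explains why the change has so large an effect.

From the compounds shown here alone, with a single step, it remains open whether the gain goes with the sulfur, the fluorines or the size of the group, and how a trifluoromethyl, a methylsulfanyl or an amine at the same place would compare. Compound 1 offers no help, as its fluoro group comes with no result.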